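Oxadiazolone series: homologated analogue of compound 3

The source may report more compounds than this note shows. Statements on the series, on what has been measured and on what is new or still open speak of the compounds shown alone.

Compound 3 `CC(C)C(c1noc(=O)[nH]1)c1ccc(-c2ccc3cccc(F)c3c2)[nH]c1=O` is measured in an ADME assay on microsomes from liver (Rattus norvegicus) for metabolic stability (on this read-out lower numbers stand for a shorter-lived compound and higher numbers for a longer-lived compound), only as a limit, giving > 3 h. Compound 2 `CCn1ncc2c(F)cc(-c3ccc(C(CC)(CC)c4ncn(C)n4)c(=O)[nH]3)cc21` likewise reaches only the limit, giving > 3 h. Compound 1 `CC(C)C(c1ncc[nH]1)c1ccc(-c2ccc3cccc(F)c3c2)[nH]c1=O` sits at the other limit, giving < 0.0667 h. Going by the values given here, the one step that is fully traced is an at least 44-fold higher number from compound 1 to compound 3 (1.65 log units; beyond the scatter), which rests on the limit of < 0.0667 h in this assay, at which 1 of the 3 values shown sits, and the limit of > 3 h in this assay, at which 2 of the 3 values shown sit, rather than on two numbers, so only its direction and a floor on its size are known.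

Compound 4 `CC(C)C(Cc1noc(=O)[nH]1)c1ccc(-c2ccc3cccc(F)c3c2)[nH]c1=O` differs from compound 3 by a group of 7 heavy atoms (3 carbon, 2 nitrogen, 2 oxygen; one five-membered aromatic ring with 3 hetero atoms) in place of a group of 6 heavy atoms (2 carbon, 2 nitrogen, 2 oxygen; one five-membered aromatic ring with 3 hetero atoms), on a saturated chain carbon bound to an aromatic carbon and a saturated chain carbon; the ring itself is kept, the change being the carbon that now carries it. The measured step from compound 1 to compound 3 concerns the exchange of one ring for another at this same carbon and does not address this change, so it gives no direction for it. With both ring-bearing analogues at the upper limit, compound 4 is expected to stay long-lived, with a number no higher from compound 3 to compound 4 (the limit leaves the size open) read as no step beyond the scatter. Compound 4 is therefore estimated at 3 h in this assay, within 1 h to 6 h, with a fair chance that only a limit is reported.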

Compound 4, half-life: > 3 h
Compound 4: only a limit was reported (the forecaster's own chance of this, stated with the estimate: 55%); the middle value lies on the limit itself.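

In this assay, the group of 7 heavy atoms on a saturated chain carbon bound to an aromatic carbon and a saturated chain carbon leaves compound 4 at the same upper limit as compound 3, so the extra carbon brings no drop that this read-out can show. Compared with the group of 5 heavy atoms, the result is an at least 44-fold higher number from compound 1 to compound 4 (1.65 log units; beyond the scatter), which makes compound 4 the second compound with the five-membered aromatic ring with 3 hetero atoms to stand clear of compound 1, though only a floor on the size is known. The step between compound 3 and compound 4 cannot be read because both sit at one limit: the limit of > 3 h in this assay, at which 3 of the 4 values shown sit.

From the compounds shown here alone, how far compound 3 and compound 4 lie past that limit remains open, so any effect of the extra carbon is unresolved. Also open, going by these compounds, is whether a carboxylic acid at this carbon would hold the number at the limit.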